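Removing a Methoxy Group from the Cinnamamide Aryl Ring

The source may hold more compounds than are shown below. What is called first, only, known or untested is meant among the compounds shown, and "the series" means these compounds.

Three compounds share a trimethoxybenzoyl-bearing anilide core joined to a cinnamamide. Compound 1 `COc1ccc(C(=O)c2cc(OC)c(OC)c(OC)c2)cc1NC(=O)/C=C/c1ccc(F)cc1` gives 3900 nM in a functional assay on DU-145 cells (Homo sapiens) for cytotoxicity, read by MTT assay, with a stated time of 72 h; on this read-out lower numbers stand for stronger inhibition and higher numbers for weaker inhibition. Compound 2 `COc1cc(/C=C/C(=O)Nc2cc(C(=O)c3cc(OC)c(OC)c(OC)c3)ccc2OC)ccc1F` gives 12100 nM in this assay, and compound 3 `COc1ccc(/C=C/C(=O)Nc2cc(C(=O)c3cc(OC)c(OC)c(OC)c3)cc(OC)c2OC)cc1OC` gives 7800 nM. The step of a 3.1-fold lower number from compound 2 to compound 1 (0.49 log units; beyond the scatter) came from hydrogen in place of methoxy on an aromatic carbon. The difference between the cores of compound 2 and compound 3 is not broken down here. Compound 4 `COc1ccc(/C=C/C(=O)Nc2cc(C(=O)c3cc(OC)c(OC)c(OC)c3)cc(OC)c2OC)cc1` has not yet been measured. It differs from compound 3 by hydrogen in place of methoxy on an aromatic carbon. This is the same kind of change as that from compound 2 to compound 1, though not the same: in the earlier pair the place is ortho to a fluoro group, whereas here it is ortho to a methoxy group. Given the modest step observed from compound 2 to compound 1, compound 4 is expected to show a 2.2-fold lower number from compound 3 to compound 4 (0.35 log units; beyond the scatter) in this assay, resting only on that single precedent. Compound 4 is thus estimated at 3500 nM, with a likely span from 1500 nM to 9000 nM.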

Compound 4, half-maximal inhibitory concentration: 10400 nM
For compound 4 the middle estimate is 3.0-fold (0.47 log units) below the measured one; measured number above the stated range.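

On the core of compound 3, putting hydrogen in place of the methoxy group ortho to a methoxy group gave a 1.3-fold higher number from compound 3 to compound 4 (0.12 log units; within the scatter) in this assay, so the lower number seen on the earlier pair did not recur. Set beside that earlier step, the same change does not carry over from one core to the other at a fixed size: the same change on two cores in this assay, a 3.1-fold lower number (0.49 log units; beyond the scatter) from compound 2 to compound 1 and a 1.3-fold higher number (0.12 log units; within the scatter) from compound 3 to compound 4, 4.1-fold (0.62 log units) apart, beyond the scatter of two such steps

This does not show what separates the two results, since the pairs differ both in the group that stays on the cinnamamide ring, fluoro in one and methoxy in the other, and in the rest of the core.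

Still open, on these data alone, is whether the outcome follows that remaining group or the rest of the core, a question that would need the same change on a core differing in only one of these. Also open, as far as these compounds go, is how an amine or a carboxylic acid in the place of the methoxy group would read on either core.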